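A few compounds are considered here, and "the series" means these few. Any claim that something is new, unique, unknown or untested is made for them only; others in the source may bear on it.

Measured so far in an ADME assay on HepG2 cells (Homo sapiens) for cytotoxicity, read by MTT assay, with a stated time of 48 h, tested at 10 uM; a higher number here means a stronger effect of the compound at the concentration tested, a lower number a weaker effect:
compound 1 `O=c1cc(-c2ccc(Cl)cc2)oc2cc(OCCCCCCCCN3CCCC3)ccc12` gives 25.7%;
compound 2 `O=c1cc(-c2ccccc2)oc2cc(OCCCCCCCCN3CCCC3)ccc12` gives 8.97%.

Going by the values given here, compound 2 stands lowest of the two in this assay; compound 1 is its nearest neighbour, and the only measured step is a number 16.7 percentage points lower from compound 1 to compound 2 (beyond the scatter). Compound 3 `O=c1cc(-c2ccc(-c3ccccc3)cc2)oc2cc(OCCCCCCCCN3CCCC3)ccc12` differs from compound 2 by phenyl in place of hydrogen on an aromatic carbon, at the same place where compound 1 carries chloro. That single step bears on the new change only loosely: taking chloro away lowered the number modestly, so putting a group back at that place is expected to raise it, by a number 13 percentage points higher from compound 2 to compound 3 (beyond the scatter). Compound 3 is therefore estimated at 22%, with a range from 5% to 40%.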

Compound 3, a percentage reported as inhibition, at one concentration (the size of the read-out at that concentration, not a potency): 71.9%
Compound 3: the middle estimate sits 49.9 percentage points below what was measured; measured number outside the range, above it.
By their numbers in this assay, from the lowest: compound 2; then compound 1; then compound 3.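

In this assay the aromatic carbon that carries chloro in compound 1 proves highly sensitive to what enters there: phenyl in place of hydrogen gives a number 62.9 percentage points higher from compound 2 to compound 3 (beyond the scatter) and exceeds the chloro step already seen. Phenyl in place of chloro still gives a number 46.2 percentage points higher from compound 1 to compound 3 (beyond the scatter) at the same carbon, so the read-out depends on which group enters, not only on hydrogen being replaced. Nothing measured accounts for this difference. Open, on these data alone, is where a methoxy group, an amine or a carboxylic acid at this place would fall relative to chloro and phenyl. Also open, as far as these compounds go, is whether the gain from 4-phenylphenyl persists with a shorter chain on the shared core.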